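Swapping the thienylmethyl arm for a carbamate-bearing chain

This account rests on a few compounds, and the source may have more. Where it says the series, first, only, none or still open, it means among the compounds named here.

Measured compounds:
- compound 1, `CCCSc1nc(Cl)c2c(n1)N(Cc1cccs1)C(C(=O)N1CCN(C)CC1)N2`: 62300 nM
- compound 2, `CCCSc1nc(Cl)c2c(n1)N(Cc1ccccc1)C(C(=O)NCCC1=CCc3ccccc31)N2`: 27000 nM

Both compounds were tested in a functional assay on MGC-803 cells (Homo sapiens) for antiproliferative activity, read by MTT assay, with a stated time of 72 h; a lower number here means a stronger inhibitor, a higher number a weaker inhibitor. Compound 1 gives 62300 nM, and compound 2 gives 27000 nM. Compound 1 thus stands with the highest number of the two; its nearest neighbour is compound 2, and the gap between them lies beyond the usual scatter of this assay. For the measured compounds named here, no pair of the measured compounds differs in only one place, so no single step can be read from them.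

Compound 3, `CCCSc1nc(Cl)c2c(n1)N(CCNC(=O)OC(C)(C)C)C(C(=O)N1CCN(C)CC1)N2`, has not yet been measured in this assay. It differs from compound 1 in one place: ((tert-butoxycarbonyl)amino)methyl in place of thiophen-2-yl on a saturated chain carbon bound to a nitrogen on an aromatic ring in a ring. Going by the values given here, no measured pair shows what this particular exchange does, so the expectation for compound 3 rests only on the weak activity of compound 1. The step from compound 1 to compound 3 is expected to be small, with no clear direction, as a 1.2-fold lower number from compound 1 to compound 3 (0.10 log units; within the scatter). Compound 3 is therefore estimated at 50000 nM in this assay, within a range from 15000 nM to 160000 nM.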

Compound 3, half-maximal inhibitory concentration: 59300 nM
For compound 3 the middle estimate is 1.2-fold (0.07 log units) below the measured one; measured number inside the range.
By their numbers in this assay, from the lowest: compound 2; then compounds 3 and 1 (each within the scatter of the next).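

In this assay, placing ((tert-butoxycarbonyl)amino)methyl in place of thiophen-2-yl on a saturated chain carbon bound to a nitrogen on an aromatic ring in a ring gives a 1.1-fold lower number from compound 1 to compound 3 (0.02 log units; within the scatter), so this pair shows no readable effect of the exchange. The five-membered aromatic ring with its sulfur can leave and an open chain with no ring can enter, bringing a hydrogen-bond donor and a larger group, while the number stays level with that of compound 1. For this pair, then, the thiophen-2-yl ring is not needed to keep the activity at the level seen for compound 1, but nothing available explains why the two compounds read alike.

Going by these compounds, it remains open whether the same flat reading would hold for a free primary amine in place of the carbamate on the 2-((tert-butoxycarbonyl)amino)ethyl chain, or for a longer chain ending in a carboxylic acid. On these data alone, it is also open whether this exchange would read the same on the amide side chain of compound 2, which differs from compound 1 in more than one place.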